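A few compounds are considered here, and "the series" means these few. Any claim that something is new, unique, unknown or untested is made for them only; others in the source may bear on it.

Three measured compounds share one core. Compound 1 `Cc1ccc2nc(Nc3nc(Nc4ccc(S(N)(=O)=O)cc4)ncc3F)sc2c1` gives 1460 nM in a functional assay on HCT-116 cells (Homo sapiens) for antiproliferative activity, read by MTT assay, with a stated time of 48 h; a lower number here means a stronger inhibitor, a higher number a weaker inhibitor. Compound 2 `Cc1cnc(Nc2ccc(S(C)(=O)=O)cc2)nc1Nc1nc2ccccc2s1` gives 760 nM in this assay. Compound 3 `Cc1ccc2nc(Nc3nc(Nc4ccc(S(C)(=O)=O)cc4)ncc3F)sc2c1` gives 9180 nM in this assay, the highest of the three numbers. Compound 4 `COc1ccc2nc(Nc3nc(Nc4ccc(S(C)(=O)=O)cc4)ncc3F)sc2c1` differs from compound 3 in one place: methoxy in place of methyl on an aromatic carbon. Within the data shown here, the only measured single step, a 6.3-fold higher number from compound 1 to compound 3 (0.80 log units; beyond the scatter), concerns a different part of the molecule and does not speak to this change; compound 2 differs from compound 3 in more than one place, so no single step toward it exists. Nothing measured bears directly on this exchange. Compound 4 is therefore expected to show a step of a 1.0-fold lower number from compound 3 to compound 4 (0.01 log units; within the scatter) in this assay, within the scatter. The estimate for compound 4 is 9000 nM, ranging from 3000 nM to 27000 nM.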

Compound 4, half-maximal inhibitory concentration: 2630 nM
The estimate for compound 4 lay 3.4-fold (0.53 log units) above the measured number; measured number outside the range, below it.
By their numbers in this assay, from the lowest: compounds 2, 1 and 4 (each within the scatter of the next, the first and the last beyond it); then compound 3.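

In this assay, among these compounds, the exchange of methyl for methoxy on this aromatic carbon gives a 3.5-fold lower number from compound 3 to compound 4 (0.54 log units; beyond the scatter) and is the first reading of any change at this place, as the earlier step concerned the sulfonyl sulfur. The number therefore responds to this substituent, at least for this one exchange with the methyl on the sulfonyl sulfur held fixed. Nothing at hand accounts for the step. The compounds shown leave open how an amine, a chlorine or ethoxy would read on this carbon, and whether methoxy gives a similar step with the amino on the sulfonyl sulfur of compound 1.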